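Ethynyl to Vinyl: One Change, Tried on Two Cores

The source may report more compounds than this note shows. Statements on the series, on what has been measured and on what is new or still open speak of the compounds shown alone.

Compound 3 `C#Cc1nc(C(=O)OCC)cs1` and compound 2 `C=Cc1nc(C(=O)OCC)cs1` differ in a single place: vinyl in place of ethynyl on an aromatic carbon. In a functional assay on NCI-H522 cells (Homo sapiens) for cytotoxicity, with a stated time of 3 days (on this read-out lower numbers stand for stronger inhibition and higher numbers for weaker inhibition), compound 3 gives 2670 nM. For compound 2 the read-out of this assay is a limit, > 40000 nM, and not a number; this is the limit of > 40000 nM in this assay, at which 1 of the 3 values shown sits. The step is an at least 14-fold higher number from compound 3 to compound 2 (1.17 log units; beyond the scatter), a large loss of potency.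

Compound 1 `C#Cc1sc(-c2ccc(F)cc2)nc1C(=O)OCC` carries a larger core; how it differs from the core of compound 3 is not broken down here. In this assay compound 1 gives 3530 nM. Compound 4 `C=Cc1sc(-c2ccc(F)cc2)nc1C(=O)OCC` has not been measured and differs from compound 1 only by vinyl in place of ethynyl on an aromatic carbon. This is the same kind of change as between compound 3 and compound 2, not the same: here the carbon is next to the ring sulfur and next to the ring atom that bears an ethoxycarbonyl group, two ring bonds from the ring nitrogen, whereas in compound 3 it is next to the ring nitrogen and the ring sulfur.

Compound 4 is expected to lose potency by an 11-fold higher number from compound 1 to compound 4 (1.05 log units; beyond the scatter), resting on the measured at least 14-fold higher number from compound 3 to compound 2 (1.17 log units; beyond the scatter). Compound 4 is estimated at about 40000 nM, between 10000 nM and 160000 nM, quite possibly reported only as a limit.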

Compound 4, half-maximal inhibitory concentration: > 40000 nM
Compound 4 gave a limit, no number; the forecaster's own chance of this, stated with the estimate: 55%; the middle value lies on the limit itself.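

The same swap of ethynyl for vinyl on the core of compound 1 also brings a large loss of potency in this assay, an at least 11-fold higher number from compound 1 to compound 4 (1.05 log units; beyond the scatter), so the drop seen on the smaller core appears again on the larger one, even though the group sits at a different place on the ring. Compound 2 and compound 4 are both reported only as a limit and not as a number: the limit of > 40000 nM in this assay, at which 2 of the 4 values shown sit. The change therefore carries over in direction and is large on both cores, but these two cases do not show that it costs the same on each, nor that it would behave this way on other cores: the same change on two cores in this assay, an at least 14-fold higher number (1.17 log units; beyond the scatter) from compound 3 to compound 2 and an at least 11-fold higher number (1.05 log units; beyond the scatter) from compound 1 to compound 4; the limit leaves it open whether they differ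

Among the compounds shown, only ethynyl and vinyl occupy this ring carbon, so it stays open how an ethyl group, a nitrile or a longer chain would read there. Also open, as far as these compounds go, is whether the loss would look the same with a carboxylic acid or an amide in place of the ethoxycarbonyl group.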